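Swapping methoxy for chloro on compound 1

A few compounds are considered here, and "the series" means these few. Any claim that something is new, unique, unknown or untested is made for them only; others in the source may bear on it.

Compound 1 `COc1ccccc1/C=c1/[nH]c(=O)/c(=C\c2ccccc2OC)n(C)c1=O` gives 1500 nM in the assay below
Compound 2 `C=CCn1c(=O)/c(=C\c2ccccc2OC)[nH]c(=O)/c1=C\c1ccccc1OC` gives 5100 nM in the assay below

In a functional assay on U-937 cells (Homo sapiens) for cytotoxicity, read by CCK-8 assay, with a stated time of 72 h (on this read-out higher numbers stand for weaker inhibition and lower numbers for stronger inhibition), compound 1 has the lower of the two numbers, 1500 nM and so it is the stronger inhibitor of this pair. For the measured compounds named here, the one measured step is a 3.4-fold higher number from compound 1 to compound 2 (0.53 log units; beyond the scatter) and it came with vinyl in place of hydrogen on a saturated chain carbon bound to an aromatic nitrogen.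

Compound 3 `COc1ccccc1/C=c1\c(=O)[nH]/c(=C/c2ccccc2Cl)c(=O)n1C` has not been measured yet. Its difference from compound 1 is chloro in place of methoxy on an aromatic carbon and it lies on an aromatic carbon of a six-membered aromatic ring of carbon only, ortho to a large group. Going by the values given here, the measured step involved a different place, and no measured compound carries chloro. That step, a 3.4-fold higher number from compound 1 to compound 2 (0.53 log units; beyond the scatter) therefore offers only a rough yardstick of size and no direction. In this assay a modest step in either direction is expected, and it may well stay within the scatter. As an estimate, that means a 1.3-fold higher number from compound 1 to compound 3 (0.12 log units; within the scatter) with little confidence in its sign. Compound 3 is expected at 2000 nM with 600 nM to 6500 nM as the estimated range.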

Compound 3, half-maximal inhibitory concentration: 100 nM
Compound 3: middle estimate off by 20-fold (1.30 log units), on the high side; measured number outside the range, below it.
By their numbers in this assay, from the lowest: compound 3; then compound 1; then compound 2.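

In this assay, chloro in place of methoxy on an aromatic carbon gives a 15-fold lower number from compound 1 to compound 3 (1.18 log units; beyond the scatter), the first sign that this place on the ring, ortho to a large group, can strongly affect the read-out. The earlier step, a 3.4-fold higher number from compound 1 to compound 2 (0.53 log units; beyond the scatter), concerned a different place, a saturated chain carbon bound to an aromatic nitrogen, and said nothing about groups on the aromatic ring. Here the exchange of a group of 2 heavy atoms for a single chlorine atom moves the number towards stronger inhibition, but no accompanying measurement shows what lies behind this shift.

The compounds shown leave open whether chloro is special or whether other groups on this carbon, such as fluoro, bromo, methyl or an amine, would give a similar number. They also leave open what chloro would do in place of the remaining methoxy group of compound 3, and whether a gain of this kind would carry over to the allyl-bearing compound 2.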